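Shortening the chain and changing the amine in a flavone series

A few compounds are considered here, and "the series" means these few. Any claim that something is new, unique, unknown or untested is made for them only; others in the source may bear on it.

Measured so far:
- compound 1 `O=c1cc(-c2ccccc2)oc2cccc(OCCCCCCCN3CCC(O)CC3)c12` gives 65 nM
- compound 2 `CN(C)CCCCCCCCCOc1ccc2oc(-c3ccccc3)cc(=O)c2c1` gives 202 nM

Of the compounds shown here, two have been measured in an assay on isolated protein (Cavia porcellus) with Sigma non-opioid intracellular receptor 1 (Homo sapiens) as the target, read by radioligand binding; on this read-out higher numbers stand for weaker inhibition and lower numbers for stronger inhibition. Compound 1 `O=c1cc(-c2ccccc2)oc2cccc(OCCCCCCCN3CCC(O)CC3)c12` gives 65 nM in this assay. Compound 2 `CN(C)CCCCCCCCCOc1ccc2oc(-c3ccccc3)cc(=O)c2c1` gives 202 nM in this assay, the higher of the two numbers and therefore the weaker binder; its gap to compound 1 lies beyond the usual scatter. No step between the two measured compounds is shown, since they differ in more than one place.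

Compound 3 `CCN(CC)CCCCCCOc1ccc2oc(-c3ccccc3)cc(=O)c2c1` has not yet been measured. It differs from compound 2 in one place: diethylamino in place of 3-(dimethylamino)propyl on a saturated chain carbon, six bonds along the chain from an oxygen on an aromatic ring. The basic amine thus sits closer to the aromatic ring, and each of its two carbon substituents grows by one carbon.

Among the compounds with values here, with only two measured compounds, nothing shows how this assay responds to such a change. The step from compound 2 to compound 3 is expected to be small, a 1.6-fold lower number from compound 2 to compound 3 (0.19 log units; within the scatter), and may well fall within the scatter, with a modest improvement slightly more likely than a loss. Compound 3 is therefore estimated at 130 nM, within a range from 40 nM to 420 nM.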

Compound 3, half-maximal inhibitory concentration: 100 nM
For compound 3 the middle estimate is 1.3-fold (0.11 log units) above the measured one; the measured number falls inside the stated range.
By their numbers in this assay, from the lowest: compounds 1 and 3 (each within the scatter of the next); then compound 2.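

In this assay, within the data shown here, placing diethylamino where 3-(dimethylamino)propyl stood, on a saturated chain carbon six bonds along the chain from an oxygen on an aromatic ring, gives a 2.0-fold lower number from compound 2 to compound 3 (0.31 log units; beyond the scatter) and supplies the first single-place comparison in this set. It shows that this position can take a change to both the chain and the amine without the number rising, and that the number instead falls by a modest amount, even though the entering group has one heavy atom fewer than the group that leaves. Read one bond further out, the same change is 6-(dimethylamino)hexyl to 3-(diethylamino)propyl, and nothing available explains why the number moves.

Since the chain and the groups on the nitrogen change together, this single step cannot show how much each contributes. A dimethylamino group on the chain of compound 3, or a diethylamino group on the chain of compound 2, would separate the two effects, while a ring amine such as pyrrolidine or morpholine on the chain of compound 3 would test whether the open-chain diethylamino group matters at all.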